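A few compounds are considered here, and "the series" means these few. Any claim that something is new, unique, unknown or untested is made for them only; others in the source may bear on it.

Compound 2 `OC/C(=C/c1cc(OCc2ccsc2)ccc1Br)c1ccccc1` is one of two compounds for which a number is in hand. In an assay on A10 cells for binding affinity to Endothelin-1 receptor (Rattus norvegicus) (on this read-out higher numbers stand for weaker inhibition and lower numbers for stronger inhibition), compound 2 gives 2100 nM, the lowest of the two numbers. The other one, compound 1 `Cc1ccccc1/C(=C\c1cc(OCc2ccsc2)ccc1Br)C(=O)O`, sits close by: in this assay compound 1 gives 3000 nM, and the gap between the two values lies within the scatter of repeated measurements, so these two numbers show no difference that can be relied on. Compound 1 and compound 2 differ in more than one place, so their pair says nothing about any single change.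

Compound 3 `Cc1ccccc1/C(=C\c1cc(OCc2ccsc2)ccc1Br)CO` has not yet been measured. It differs from compound 2 in one place: methyl in place of hydrogen on an aromatic carbon, so that the phenyl ring becomes a 2-methylphenyl ring. Going by the values given here, no measured pair isolates this change. The expected step from compound 2 to compound 3 in this assay is therefore small, a 1.1-fold lower number from compound 2 to compound 3 (0.02 log units; within the scatter), with no direction preferred beyond the scatter. Compound 3 is accordingly estimated to give about 2000 nM in this assay, with a range from 700 nM to 6000 nM.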

Compound 3, half-maximal inhibitory concentration: 600 nM
Compound 3: the middle estimate sits 3.3-fold (0.52 log units) above what was measured; measured number outside the range, below it.
By their numbers in this assay, from the lowest: compound 3; then compounds 2 and 1 (each within the scatter of the next).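

In this assay, going by these compounds alone, the addition of methyl on an aromatic carbon, ortho to a large group, turns the phenyl ring into a 2-methylphenyl ring and gives a 3.5-fold lower number from compound 2 to compound 3 (0.54 log units; beyond the scatter), the first reading of a single change at this position, and one that lies beyond the scatter, so this small addition to the ring is not neutral in this pair. With the 2-methylphenyl ring held constant, the second single change, hydroxymethyl in place of carboxy on the chain, gives a 5.0-fold lower number from compound 1 to compound 3 (0.70 log units; beyond the scatter), which is also beyond the scatter and shows that the two groups are not interchangeable on this core. Nothing measured here explains either step.

The compounds shown do not reveal whether a different group at the same ring position, such as ethyl, methoxy or chlorine, would lower the number further, raise it or leave it unchanged. They also leave open how an amine or an amide would compare with hydroxymethyl and carboxy on the chain, and whether methyl would have a similar effect when paired with carboxy rather than hydroxymethyl.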